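A few compounds are considered here, and "the series" means these few. Any claim that something is new, unique, unknown or untested is made for them only; others in the source may bear on it.

Measured so far in an ADME assay on microsomes from liver (Mus musculus, strain NMRI) for metabolic stability, tested at 2.5 uM; on this read-out lower numbers stand for slow clearance and higher numbers for fast clearance:
- Compound 1 `Clc1ccc(Cn2nnc3c(Br)cccc32)cc1` gives 2 mL/min/g
- Compound 2 `Brc1cccc2c1nnn2CC1CCC1` gives 11.4 mL/min/g

Of the compounds shown here, two have been measured. Compound 1 shows the lower number and compound 2 the higher; the gap between them lies beyond the usual scatter of this assay, so compound 2 stands as the faster-cleared of the two on the numbers shown. Among the measured compounds shown here, no step between measured compounds that differ in only one place has been recorded, so what follows rests on these two values alone.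

Compound 3 `CCCn1nnc2c(Br)cccc21` has not yet been measured. Its difference from compound 2 is counted as ethyl in place of cyclobutyl on a saturated chain carbon bound to an aromatic nitrogen.

Compound 3 is expected to give about 7 mL/min/g in this assay, within a range from 3 mL/min/g to 16 mL/min/g. This estimate corresponds to an expected step of a 1.6-fold lower number from compound 2 to compound 3 (0.21 log units; within the scatter), a modest move toward slower clearance, starting from the value of compound 2 at 11.4 mL/min/g. The shift is expected to be small enough that it may not clear the scatter of repeated measurements.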

Compound 3, intrinsic clearance in a liver preparation (reported as CLH), per the amount of preparation that the assay uses: 7.7 mL/min/g
Compound 3: middle estimate off by 1.1-fold (0.04 log units), on the low side, and the stated range covers the measured number.
By their numbers in this assay, from the lowest: compound 1; then compounds 3 and 2 (each within the scatter of the next).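

In this assay, among the compounds shown here, ethyl in place of cyclobutyl on a saturated chain carbon bound to an aromatic nitrogen, which can also be read as cyclobutylmethyl to propyl, gives a 1.5-fold lower number from compound 2 to compound 3 (0.17 log units; within the scatter), the first comparison here of compounds that differ in one place. At this position, then, the four-membered ring can be given up for an open chain with no difference that repeated measurements could distinguish, so the ring is not required for a number in this range. Nothing available here accounts for the size of this step, and its cause remains unknown.

The compounds shown leave open how other groups at this position would behave, such as a longer chain, a cyclohexyl ring, or a chain carrying an amine or a carboxylic acid. They also leave open whether a plain benzyl group, without the chlorine carried by compound 1 at 2 mL/min/g, would give a number close to that of compound 1 or close to those of the two alkyl compounds.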